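The compounds below may be only part of what the source reports. "The series", "measured", "known", "first", "only" and "open" are said of these compounds alone.

Measured compounds in an assay on HeLa cells with Bile acid receptor (Homo sapiens) as the target, read by a luciferase reporter, with a stated time of 24 h; a higher number here means that more compound is needed for the effect, a lower number that less compound is needed:
compound 1 `CC(C)(C)c1ccc(C(=O)NCc2ccc(C(N)=O)cc2)cc1` gives 3800 nM
compound 2 `CC(C)(C)c1ccc(C(=O)NCc2ccc(NS(C)(=O)=O)cc2)cc1` gives 44 nM
compound 3 `CC(=O)Nc1ccc(CNC(=O)c2ccc(C(C)(C)C)cc2)cc1` gives 2900 nM

Compound 3 stands second highest of the three numbers; compound 1 is nearest, a 1.3-fold lower number from compound 1 to compound 3 (0.12 log units; within the scatter), and compound 2 furthest, a 66-fold higher number from compound 2 to compound 3 (1.82 log units; beyond the scatter). Compound 4 `COc1ccc(CNC(=O)c2ccc(C(C)(C)C)cc2)cc1` is not yet measured; it differs from compound 3 by methoxy in place of acetamido on an aromatic carbon.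

Going by the values given here, the steps that bear on this change are a 1.3-fold lower number from compound 1 to compound 3 (0.12 log units; within the scatter) and a 66-fold higher number from compound 2 to compound 3 (1.82 log units; beyond the scatter): the carbamoyl and acetamido variants sit together, while only the methanesulfonamido variant gives a low number. Methoxy at this position has no measured counterpart. In the absence of the methanesulfonamido group, compound 4 is expected to stay near the weaker pair, with a step of a 1.7-fold higher number from compound 3 to compound 4 (0.24 log units; within the scatter) in this assay. Compound 4 is therefore estimated at 5000 nM, range 1500 nM to 20000 nM.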

Compound 4, half-maximal effective concentration: 150 nM
Compound 4: the middle estimate sits 33-fold (1.52 log units) above what was measured, and the stated range ends above it.
By their numbers in this assay, from the lowest: compound 2; then compound 4; then compounds 3 and 1 (each within the scatter of the next).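

Methoxy on this aromatic carbon breaks the earlier picture, in which only the methanesulfonamido variant gave a low number: the series shows a 19-fold lower number from compound 3 to compound 4 (1.29 log units; beyond the scatter) and a 25-fold lower number from compound 1 to compound 4 (1.40 log units; beyond the scatter). A low number therefore does not require the methanesulfonamido group, although a 3.4-fold higher number from compound 2 to compound 4 (0.53 log units; beyond the scatter) still leaves that group with the lower number by a modest margin. No evidence available here accounts for this change.

Still open, on these data alone, is how a hydroxyl, an ethoxy or a dimethylamino group at this place, para to a large group, would compare with methoxy and methanesulfonamido.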